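Aminothiophene trimethoxybenzoyl series: aryl variation on the ring sulfur side

The compounds below may be only part of what the source reports. "The series", "measured", "known", "first", "only" and "open" are said of these compounds alone.

Measured so far:
- compound 1 `COc1cc(C(=O)c2sc(-c3ccc(Cl)cc3)cc2N)cc(OC)c1OC`: 93 nM
- compound 2 `COc1cc(C(=O)c2sc(-c3ccc(C(F)(F)F)cc3)cc2N)cc(OC)c1OC`: 370 nM
- compound 3 `COc1ccc(-c2cc(N)c(C(=O)c3cc(OC)c(OC)c(OC)c3)s2)cc1OC`: 40 nM

In a functional assay on L1210 cells (Mus musculus) for antiproliferative activity (a higher number here means a weaker inhibitor, a lower number a stronger inhibitor), compound 2 gives the highest number of the three. The nearest is compound 1: a 4.0-fold higher number from compound 1 to compound 2 (0.60 log units; beyond the scatter). The furthest is compound 3: a 9.3-fold lower number from compound 2 to compound 3 (0.97 log units; beyond the scatter). Between compound 1 and compound 3 the step is a 2.3-fold lower number from compound 1 to compound 3 (0.37 log units; beyond the scatter).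

Compound 4 `COc1cccc(-c2cc(N)c(C(=O)c3cc(OC)c(OC)c(OC)c3)s2)c1` has not yet been measured in this assay. Its change from compound 2: 3-methoxyphenyl in place of 4-(trifluoromethyl)phenyl on an aromatic carbon

Going by the values given here, two measured steps bear on this. The step of a 9.3-fold lower number from compound 2 to compound 3 (0.97 log units; beyond the scatter) shows what removing the 4-(trifluoromethyl)phenyl for a methoxy-bearing phenyl did, and the step of a 4.0-fold higher number from compound 1 to compound 2 (0.60 log units; beyond the scatter) shows the 4-(trifluoromethyl)phenyl as the weakest of the three aryl groups. A single methoxy group is expected to land between the result for compound 1 and that for compound 3, so a lower number than compound 2 is expected, roughly a 4.9-fold lower number from compound 2 to compound 4 (0.69 log units; beyond the scatter). Compound 4 is estimated at 75 nM, with a range from 25 nM to 250 nM.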

Compound 4, half-maximal inhibitory concentration: 22 nM
Beside the measured number, compound 4's estimate is 3.4-fold (0.53 log units) above it; measured number outside the range, below it.
By their numbers in this assay, from the lowest: compounds 4 and 3 (each within the scatter of the next); then compound 1; then compound 2.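

In this assay, putting the 3-methoxyphenyl group on this aromatic carbon next to the ring sulfur gives the largest step in the set so far: a 17-fold lower number from compound 2 to compound 4 (1.23 log units; beyond the scatter). Taking one methoxy from the 3,4-dimethoxyphenyl group changes nothing that can be read, a 1.8-fold lower number from compound 3 to compound 4 (0.26 log units; within the scatter), and the 3-methoxyphenyl group also stands clear of the 4-chlorophenyl group, a 4.2-fold lower number from compound 1 to compound 4 (0.63 log units; beyond the scatter), so among these four compounds both methoxy-bearing aryl groups give lower numbers than the chloro and trifluoromethyl ones, with no exception. No measurement accompanies these numbers that could account for them.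

The compounds shown leave open whether an unsubstituted phenyl would give a number like these or whether the methoxy is needed at all. A 4-methoxyphenyl, a 3-hydroxyphenyl or a 3-aminophenyl group would test how much depends on the methoxy and on where it sits.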